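Working notes: from compound 3 to compound 4

This account rests on a few compounds, and the source may have more. Where it says the series, first, only, none or still open, it means among the compounds named here.

Measured so far in a functional assay on PC-3 cells (Homo sapiens) for cytotoxicity, read by sulforhodamine B assay, with a stated time of 48 h, tested at 0.01 uM; on this read-out lower numbers stand for a stronger effect and higher numbers for a weaker effect at the one concentration tested:
compound 1 `COc1cc(-c2cc(/C=C/C(=O)c3ccc(N)cc3)[nH]n2)cc(OC)c1OC` gives 97%
compound 2 `COc1cc(-c2cc(/C=C/C(=O)c3ccc(Cl)c(Cl)c3)[nH]n2)cc(OC)c1OC` gives 95%
compound 3 `COc1ccc(C(=O)/C=C/c2cc(-c3cc(OC)c(OC)c(OC)c3)n[nH]2)cc1OC` gives 96%

Compound 3 stands second highest of the three numbers. Its nearest neighbour is compound 1, with a number 1 percentage points lower from compound 1 to compound 3 (within the scatter); its furthest is compound 2, with a number 1 percentage points higher from compound 2 to compound 3 (within the scatter); the remaining pair shows a number 2 percentage points lower from compound 1 to compound 2 (within the scatter). All three steps are within the scatter.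

Compound 4 `COc1ccc(C(=O)/C=C/c2cc(-c3cc(OC)c(OC)c(OC)c3)n[nH]2)cc1` differs from compound 3 in one place: hydrogen in place of methoxy on an aromatic carbon. Going by the values given here, the measured steps all exchange the whole aryl on the carbonyl carbon, and none of them removes a methoxy from that ring, so no step bears on this change directly. Since every exchange of that aryl left this assay unmoved, the expected step of no change at the digits printed from compound 3 to compound 4 (within the scatter) is none beyond the scatter. Compound 4 is therefore expected to give 96%, within 88% to 100%.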

Compound 4, a percentage reported as activity, at one concentration (the size of the read-out at that concentration, not a potency): 99%
Estimate against measurement, compound 4: 3 percentage points below; measured number inside the range.
By their numbers in this assay, from the lowest: compounds 2, 3, 1 and 4 (each within the scatter of the next).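

Hydrogen in place of methoxy on an aromatic carbon reads in this assay as a number 3 percentage points higher from compound 3 to compound 4 (within the scatter), a direct reading at this position that the whole-aryl exchanges did not give. The 4-methoxyphenyl group also stays level with the other aryls, with a number 4 percentage points higher from compound 2 to compound 4 (within the scatter) and a number 2 percentage points higher from compound 1 to compound 4 (within the scatter), so these four compounds cannot be told apart here. Nothing available accounts for these small steps. On these data alone, whether a hydroxyl, an amine or a longer alkoxy chain at this position would move the read-out beyond the scatter stays open. So does any step at another concentration.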